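Dimethylamino to diethylamino: working notes on the series

This account rests on a few compounds, and the source may have more. Where it says the series, first, only, none or still open, it means among the compounds named here.

In a functional assay on A549 cells (Homo sapiens) for cytotoxicity, read by MTT assay, with a stated time of 72 h (a higher number here means a weaker inhibitor, a lower number a stronger inhibitor), compound 1 (`CCN(CC)Cc1ccc2nc(NC(=O)N/N=C/c3cn(Cc4ccccc4)c4ccccc34)sc2c1`) gives 3330 nM and compound 2 (`CN(C)Cc1ccc2nc(NC(=O)N/N=C/c3cn(Cc4ccc(Cl)c(Cl)c4)c4ccccc34)sc2c1`) gives 940 nM, the lower of the two numbers, with a gap beyond the scatter. Compound 3 (`CCN(CC)Cc1ccc2nc(NC(=O)N/N=C/c3cn(Cc4ccc(Cl)c(Cl)c4)c4ccccc34)sc2c1`) carries diethylamino in place of dimethylamino on a saturated chain carbon bound to an aromatic carbon. Within the data shown here, no measured pair yet isolates a single change. The expected outcome in this assay is no shift beyond the scatter, and the estimated step is a 1.2-fold higher number from compound 2 to compound 3 (0.07 log units; within the scatter). For compound 3 the estimated value is 1100 nM, with an expected range from 450 nM to 2700 nM.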

Compound 3, half-maximal inhibitory concentration: 1470 nM
The estimate for compound 3 lay 1.3-fold (0.13 log units) below the measured number; the measured number falls inside the stated range.
By their numbers in this assay, from the lowest: compounds 2 and 3 (each within the scatter of the next); then compound 1.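

In this assay the swap of dimethylamino for diethylamino on a saturated chain carbon bound to an aromatic carbon gives a 1.6-fold higher number from compound 2 to compound 3 (0.19 log units; within the scatter) and so shows that this position accepts the larger amine without a shift beyond the scatter. Among these compounds, the change of phenyl to 3,4-dichlorophenyl on a saturated chain carbon bound to an aromatic nitrogen gives a 2.3-fold lower number from compound 1 to compound 3 (0.36 log units; beyond the scatter) and is the only single change here that reaches beyond the scatter. Nothing available bears on the cause of either step.

Going by these compounds, whether morpholine or a primary amine would fit at the amine position stays open. So does whether a single chlorine on the phenyl would give a similar step.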